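Moving a Single Fluorine on the Pendant Fluorophenyl Group

The source may hold more compounds than are shown below. What is called first, only, known or untested is meant among the compounds shown, and "the series" means these compounds.

Compound 2 `COc1cc2c(Oc3ccc(NC(=O)NN4C(=O)CSC4c4c(F)cccc4F)cc3)ccnc2cc1OC1CCN(C(=O)NC(C)C)CC1` holds the lower of the two numbers in hand: in a functional assay on HT-29 cells (Homo sapiens) for inhibition, read by MTT assay (on this read-out higher numbers stand for weaker inhibition and lower numbers for stronger inhibition), compound 2 gives 310 nM, while compound 1 `COc1cc2c(Oc3ccc(NC(=O)NN4C(=O)CSC4c4ccc(F)cc4F)cc3)ccnc2cc1OC1CCN(C(=O)NC(C)C)CC1` gives 950 nM. Within the data shown here, the one measured step, a 3.1-fold lower number from compound 1 to compound 2 (0.49 log units; beyond the scatter), shows that where the fluorines sit on this group can matter beyond the scatter. Compound 3 `COc1cc2c(Oc3ccc(NC(=O)NN4C(=O)CSC4c4cccc(F)c4)cc3)ccnc2cc1OC1CCN(C(=O)NC(C)C)CC1` differs from compound 2 by 3-fluorophenyl in place of 2,6-difluorophenyl on a saturated ring carbon. Among the measured compounds shown here, no measured step covers a 3-fluorophenyl, so the direction is uncertain. A modest rise in this assay is nonetheless expected for compound 3, a 2.3-fold higher number from compound 2 to compound 3 (0.35 log units; beyond the scatter). Compound 3 is estimated at 700 nM, within 250 nM to 2000 nM.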

Compound 3, half-maximal inhibitory concentration: 670 nM
The estimate for compound 3 lay 1.0-fold (0.02 log units) above the measured number; the range from low to high includes it.
By their numbers in this assay, from the lowest: compound 2; then compounds 3 and 1 (each within the scatter of the next).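

In this assay the 2,6-difluorophenyl of compound 2 keeps its lead over a group with one fluorine fewer (a 2.2-fold higher number from compound 2 to compound 3 (0.33 log units; beyond the scatter)). The 3-fluorophenyl and the 2,4-difluorophenyl cannot be told apart (a 1.4-fold lower number from compound 1 to compound 3 (0.15 log units; within the scatter)), so of these three groups only the 2,6-difluorophenyl stands out. Nothing available explains why the number and placing of the fluorines should matter here.

Still open, going by these compounds, is how a plain phenyl, or a phenyl carrying chlorine or a methoxy group, would compare with these three.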